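The source may hold more compounds than are shown below. What is called first, only, known or untested is meant among the compounds shown, and "the series" means these compounds.

Compound 2 `O=S(=O)(NCCCNCc1ccc(Cl)c(C(F)(F)F)c1)c1cc(C(F)(F)F)cc(C(F)(F)F)c1` gives 11000 nM in a functional assay on HT-29 cells (Homo sapiens) for inhibition, read by MTT assay, with a stated time of 72 h (a higher number here means a weaker inhibitor of growth, a lower number a stronger inhibitor of growth), and holds the lowest of the two plain numbers shown in the series. Compound 1 `O=S(=O)(NCCCNCc1ccccc1Cl)c1cc(C(F)(F)F)cc(C(F)(F)F)c1` gives 20000 nM in this assay, and the step of a 1.8-fold lower number from compound 1 to compound 2 (0.26 log units; within the scatter). Compound 3 `CN(CCCNS(=O)(=O)c1cc(C(F)(F)F)cc(C(F)(F)F)c1)Cc1ccccc1` returns only a limit in this assay, > 50000 nM; this is the limit of > 50000 nM in this assay, at which 1 of the 3 values shown sits. The step of an at least 2.5-fold higher number from compound 1 to compound 3 (0.39 log units; beyond the scatter). Compound 4 `O=S(=O)(NCCCNCc1cccc2ccccc12)c1cc(C(F)(F)F)cc(C(F)(F)F)c1` has not yet been measured; it differs from compound 2 by naphthalen-1-yl in place of 4-chloro-3-(trifluoromethyl)phenyl on a saturated chain carbon bound to an amine nitrogen. Among the measured compounds shown here, only the step from compound 1 to compound 2 alters the same position, and that one stayed within the scatter, so no step beyond the scatter is expected in this assay. The estimate for compound 4 is 12000 nM, with a range from 5000 nM to 30000 nM. This corresponds to an expected step of a 1.1-fold higher number from compound 2 to compound 4 (0.04 log units; within the scatter).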

Compound 4, concentration for 50% growth inhibition: 2600 nM
Estimate against measurement, compound 4: 4.6-fold (0.66 log units) above, and the stated range ends above it.
By their numbers in this assay, from the lowest: compound 4; then compounds 2 and 1 (each within the scatter of the next). At a limit, above all of these: compound 3.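

In this assay, the change on a saturated chain carbon bound to an amine nitrogen now gives a step beyond the scatter: a 4.2-fold lower number from compound 2 to compound 4 (0.63 log units; beyond the scatter), and a 7.7-fold lower number from compound 1 to compound 4 (0.89 log units; beyond the scatter). The step between the two chlorinated phenyl groups stayed within the scatter, so this position does respond to the aryl group, and naphthalen-1-yl, with its 2 six-membered aromatic rings, gives the lowest number shown. Nothing at hand accounts for this gain. Open, on these data alone, is whether naphthalen-2-yl or a quinoline ring would match naphthalen-1-yl. Also open, as far as these compounds go, is how naphthalen-1-yl behaves with a methyl group on the amine nitrogen.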